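The source may hold more compounds than are shown below. What is called first, only, known or untested is meant among the compounds shown, and "the series" means these compounds.

Measured set in an ADME assay on MCF-10A cells (Homo sapiens) for cytotoxicity, read by sulforhodamine B assay, with a stated time of 48 h; on this read-out lower numbers stand for stronger inhibition of growth and higher numbers for weaker inhibition of growth:
Compound 1 `Cc1ccc2nc(/N=C3\C(=O)N(CN4CCCCC4)c4ccccc43)sc2c1` gives 38900 nM.
Compound 2 `O=C1C(=O)N(CN(c2ccccc2)c2ccccc2)c2ccccc21` gives 73000 nM.
Compound 3 `CN(C)CN1C(=O)C(=O)c2c(Br)cccc21` gives 67800 nM.

Compound 3 stands second highest of the three numbers; its gap to compound 2 and its gap to compound 1 both fall within the usual scatter of repeated measurements, so no order among the three compounds can be read from these values. Among the measured compounds shown here, no step between measured compounds that differ in one place is available in this set. Compound 4 `CCN(CC)CN1C(=O)C(=O)c2c(Br)cccc21` differs from compound 3 by diethylamino in place of dimethylamino on a saturated chain carbon bound to an amide-type nitrogen in a ring. With no shown step to rest on, the expected step of a 1.1-fold lower number from compound 3 to compound 4 (0.05 log units; within the scatter) is none beyond the scatter, in either direction. For compound 4 in this assay the estimate is 60000 nM, with a range from 25000 nM to 150000 nM.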

Compound 4, concentration for 50% growth inhibition: 113000 nM
For compound 4 the middle estimate is 1.9-fold (0.27 log units) below the measured one; measured number inside the range.
By their numbers in this assay, from the lowest: compounds 1, 3, 2 and 4 (each within the scatter of the next, the first and the last beyond it).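

Among the compounds shown here, the first one-place step in the set, diethylamino in place of dimethylamino on a saturated chain carbon bound to an amide-type nitrogen in a ring, reads in this assay as a 1.7-fold higher number from compound 3 to compound 4 (0.22 log units; within the scatter) and so shows no change that can be told from the scatter. At this place, two added carbons in the amine leave the read-out unresolved. No measurement on hand offers an explanation for this step.

Still open, going by these compounds, is how morpholine or a longer chain carrying the amine would read on the core of compound 3. Also open, on these data alone, is whether any group at this place moves the number beyond the scatter.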